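Losing the ethynyl group from a weakly cytotoxic amide

The source may report more compounds than this note shows. Statements on the series, on what has been measured and on what is new or still open speak of the compounds shown alone.

In a functional assay on B16 cells (Mus musculus) for cytotoxicity, read by MTT assay, with a stated time of 48 h (on this read-out higher numbers stand for weaker inhibition and lower numbers for stronger inhibition), compound 1 `C#Cc1ccc(NC(=O)c2cn(CC(=O)OCC)nn2)cc1` gives > 100000 nM as its result. That result is a limit of the assay and not a number. Among the compounds with values here, compound 2 `C#Cc1ccc(NC(=O)c2cn(CCOC(C)=O)nn2)cc1` gives 79000 nM and holds the only actual number so far. Within the data shown here, the one measured step, an at least 1.2-fold lower number from compound 1 to compound 2 (0.10 log units; that floor lies within the scatter), changes a different part of the molecule and leaves the ethynyl group untouched. Among the measured compounds shown here, no measured step therefore bears directly on the next change.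

Compound 3 `CC(=O)OCCn1cc(C(=O)Nc2ccccc2)nn1` has hydrogen in place of ethynyl on an aromatic carbon. With only the small step of an at least 1.2-fold lower number from compound 1 to compound 2 (0.10 log units; that floor lies within the scatter) as a guide and compound 2 at 79000 nM as the anchor, no shift beyond the scatter is expected in this assay. The expected step is a 1.2-fold higher number from compound 2 to compound 3 (0.08 log units; within the scatter) and would be no real change. For compound 3 the estimated value is 95000 nM, with an expected range from 40000 nM to 220000 nM.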

Compound 3, half-maximal inhibitory concentration: > 100000 nM
Compound 3: a limit, no number; the forecaster's own chance of this, stated with the estimate: 50%; middle value at least 1.0-fold (0.02 log units) away from the limit.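

Within the data shown here, with hydrogen in place of ethynyl on an aromatic carbon, para to a large group, this assay gives the first reading at this position: an at least 1.2-fold higher number from compound 2 to compound 3 (0.10 log units; that floor lies within the scatter). Compound 3 gives > 100000 nM, which is a limit of the assay and not a number. The step is therefore only a floor that stays within the scatter, so it shows no measurable role for ethynyl here, yet it cannot exclude a larger difference, because the reading stops at this limit: the limit of > 100000 nM in this assay, at which 2 of the 3 values shown sit.

From the compounds shown here alone, whether a nitrile, a methyl or an amine at this position would give a number within the reach of this assay remains open. Also open, going by these compounds, is whether a carboxylic acid or a longer chain in place of the acetoxymethyl group would do so on the same core.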